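The source may report more compounds than this note shows. Statements on the series, on what has been measured and on what is new or still open speak of the compounds shown alone.

Compound 1 `CC(C)(C)CC[C@H](c1ccc(C(=O)NCc2nn[nH]n2)cc1)N1C(=O)C(c2cncc(Cl)c2)=N[C@]12CC[C@@H](C(C)(C)C)CC2` gives 84 nM in an assay on membranes from liver for displacement of a labelled ligand from Glucagon receptor (Mus musculus), read by scintillation counting, with a stated time of 60 min; on this read-out lower numbers stand for stronger inhibition and higher numbers for weaker inhibition. Compound 3 `CC(C)(C)CC[C@H](c1ccc(C(=O)NCc2nn[nH]n2)cc1)N1C(=O)C(c2cccc(C(F)(F)F)c2)=N[C@]12CC[C@@H](C(C)(C)C)CC2` gives 140 nM in this assay. Compound 2 `C[C@H](c1ccc(C(=O)NCCC(=O)O)cc1)N1C(=O)C(c2ccccc2F)=N[C@]12CC[C@@H](C(C)(C)C)CC2` gives only a limit in this assay, > 10000 nM, which is the limit of > 10000 nM in this assay, at which 1 of the 3 values shown sits.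

Compound 4 `C[C@H](c1ccc(C(=O)NCCC(=O)O)cc1)N1C(=O)C(c2cccc(Cl)c2F)=N[C@]12CC[C@@H](C(C)(C)C)CC2` is not yet measured. It differs from compound 2 by chloro in place of hydrogen on an aromatic carbon. Going by the values given here, the one measured step, a 1.7-fold higher number from compound 1 to compound 3 (0.22 log units; within the scatter), exchanges a whole ring at another place and on other compounds, so it says little about this change. With compound 2 resting at a limit, no direction can be drawn from the numbers shown. Compound 4 is expected to give about 8000 nM, between 1500 nM and 30000 nM. The step of an at least 1.2-fold lower number from compound 2 to compound 4 (0.09 log units; that floor lies within the scatter) is therefore expected to stay within the scatter, and a further limit is likely.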

Compound 4, half-maximal inhibitory concentration: 4000 nM
Beside the measured number, compound 4's estimate is 2.0-fold (0.30 log units) above it; the range from low to high includes it.
By their numbers in this assay, from the lowest: compounds 1 and 3 (each within the scatter of the next); then compound 4. At a limit, above all of these: compound 2.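

Chloro on the aromatic carbon ortho to the fluoro group, turning 2-fluorophenyl into 3-chloro-2-fluorophenyl, gives an at least 2.5-fold lower number from compound 2 to compound 4 (0.39 log units; beyond the scatter). This is the first step shown that lies beyond the scatter, so this position responds to a single added chlorine atom. The value of compound 2 is a limit and not a number: the limit of > 10000 nM in this assay, at which 1 of the 4 values shown sits.

Going by these compounds, only a floor is therefore known for this step, and its full size stays open. Also open, on these data alone, is whether a bromo, methyl or amine group at this position would lower the number further.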